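Compound 4: a smaller ring group on the shared core

This account rests on a few compounds, and the source may have more. Where it says the series, first, only, none or still open, it means among the compounds named here.

Compound 1 `Cc1cc(OC[C@@H]2CN(C)c3ccccc3O2)cc(C)c1C(=O)Nc1cccc(CC(=O)O)c1`, compound 2 `Cc1cc(OC[C@@H]2CN(C)c3ccccc3O2)ccc1C(=O)Nc1cc(CC(=O)O)ccc1Cl` and compound 3 `Cc1cc(OC[C@@H]2CN(C)c3ccccc3O2)cc(C)c1C(=O)Nc1cc(CC(=O)O)ccc1Cl` share one core and were tested in an assay on CHO cells for displacement of a labelled ligand from prostacyclin receptor (Homo sapiens), read by scintillation counting, with a stated time of 30 min; on this read-out higher numbers stand for weaker inhibition and lower numbers for stronger inhibition. In this assay compound 1 gives > 10000 nM, which is a limit of the assay rather than a number. Compound 2 gives 1800 nM in this assay. Compound 3 gives > 10000 nM in this assay, again a limit and not a number. The step of an at least 5.5-fold higher number from compound 2 to compound 3 (0.74 log units; beyond the scatter) is thus the only readable one, while a step that the two limits leave unreadable from compound 1 to compound 3. Because (the limit of > 10000 nM in this assay, at which 2 of the 3 values shown sit), compound 3 cannot be placed more precisely than at that limit.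

Compound 4 `Cc1cc(OC[C@@H]2Cc3ccccc3O2)cc(C)c1C(=O)Nc1cc(CC(=O)O)ccc1Cl` differs from compound 3 by a group of 9 heavy atoms (8 carbon, 1 oxygen; one five-membered non-aromatic ring with 1 hetero atom, one six-membered aromatic ring of carbon only) in place of a group of 11 heavy atoms (9 carbon, 1 nitrogen, 1 oxygen; one six-membered non-aromatic ring with 2 hetero atoms, one six-membered aromatic ring of carbon only), on a saturated chain carbon bound to an oxygen on an aromatic ring. Among the compounds with values here, neither measured step touches this part of the molecule, so no measured step bears on the change directly, and nothing among the measured compounds points to a gain. Compound 4 is therefore expected to stay near where compound 3 stands, so the estimated step that the limit leaves unreadable from compound 3 to compound 4 means no expected change beyond the scatter. Compound 4 is estimated at 15000 nM in this assay, within a range from 5000 nM to 50000 nM, with a real chance that only a limit is again returned.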

Compound 4, inhibition constant: > 10000 nM
Compound 4: no number, only a limit (the forecaster's own chance of this, stated with the estimate: 60%); the middle value does not contradict the limit.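

The change from compound 3 to compound 4 cannot be read as a step, because both compounds give only a limit of the assay and no number: the limit of > 10000 nM in this assay, at which 3 of the 4 values shown sit. The compounds shown leave open how strongly compound 3 and compound 4 actually inhibit, and whether the smaller ring group makes any difference.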